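Pyrazole for pyridine on the chlorophenyl sulfone urea

This account rests on a few compounds, and the source may have more. Where it says the series, first, only, none or still open, it means among the compounds named here.

Measured so far:
compound 1 `NS(=O)(=O)c1ccc(NC(=O)NCc2ccncc2)cc1` in an assay on isolated protein for activation of Nicotinamide phosphoribosyltransferase (Homo sapiens) (on this read-out lower numbers stand for an effect already at smaller amounts and higher numbers for an effect only at larger amounts of compound), gives 14300 nM
compound 2 `O=C(NCc1cn[nH]c1)Nc1ccc(S(=O)(=O)c2ccccc2)cc1` gives 28 nM
compound 3 `O=C(NCc1ccncc1)Nc1ccc(S(=O)(=O)c2ccc(Cl)cc2)cc1` gives 126 nM

Compound 3 stands second highest of the three numbers; compound 2 sits lower, compound 1 far higher. The step of a 110-fold lower number from compound 1 to compound 3 (2.05 log units; beyond the scatter) is the only one measured in a single place.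

Compound 4 `O=C(NCc1cn[nH]c1)Nc1ccc(S(=O)(=O)c2ccc(Cl)cc2)cc1` differs from compound 3 by 1H-pyrazol-4-yl in place of pyridin-4-yl on a saturated chain carbon bound to an amide-type nitrogen. For the measured compounds named here, no measured step isolates this change; compound 2 carries the same pyrazole but an unsubstituted phenyl sulfone, so compound 2 and compound 3 differ in two places. The value of compound 2 is the only pointer, and it suggests the pyrazole is tolerated at least as well as the pyridine.

Compound 4 is therefore expected to give 40 nM (range 12 nM to 130 nM), a step of a 3.2-fold lower number from compound 3 to compound 4 (0.50 log units; beyond the scatter) toward lower numbers, though the step may stay within the scatter.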

Compound 4, half-maximal effective concentration: 23 nM
Estimate against measurement, compound 4: 1.7-fold (0.24 log units) above; the range from low to high includes it.
By their numbers in this assay, from the lowest: compounds 4 and 2 (each within the scatter of the next); then compound 3; then compound 1.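

In this assay, the change from pyridin-4-yl to 1H-pyrazol-4-yl on the chlorophenyl sulfone now stands alone, as a 5.5-fold lower number from compound 3 to compound 4 (0.74 log units; beyond the scatter) and beyond the scatter, so this position responds to the ring that sits on the saturated chain carbon. With the pyrazole present, chloro in place of hydrogen on an aromatic carbon gives a 1.2-fold lower number from compound 2 to compound 4 (0.09 log units; within the scatter) and no change beyond the scatter. Nothing available explains the pyrazole step.

Open, as far as these compounds go, is whether 1-methyl-1H-pyrazol-4-yl, which carries a methyl on the ring nitrogen, keeps these values. From the compounds shown here alone, a longer chain to the pyrazole is equally open.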